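Cytotoxicity notes on a chlorophenoxy amide series

This account rests on a few compounds, and the source may have more. Where it says the series, first, only, none or still open, it means among the compounds named here.

Among the measured compounds shown here, compound 1 `Cc1ccc(NC(=S)OCCNC(=O)C(C)(C)Oc2ccc(Cl)cc2)cc1` is one of three compounds measured in an ADME assay on HUVEC cells (Homo sapiens) for cytotoxicity, read by MTT assay, with a stated time of 48 h; on this read-out lower numbers stand for stronger inhibition and higher numbers for weaker inhibition. In this assay compound 1 gives 661000 nM. Compound 2 `CC(C)(Oc1ccc(Cl)cc1)C(=O)Oc1ccc(-c2cc(=S)ss2)cc1` gives 617000 nM, and compound 3 `Cc1cnc(C(=O)Oc2ccc(C(N)=S)cc2)c[n+]1[O-]` gives 714000 nM. Compound 1 stands second highest of the three numbers, yet its gaps to compound 2 and to compound 3 both lie within the usual scatter, so the three cannot be told apart and no order among them is read. For the measured compounds named here, no step between measured compounds that differ in one place is available.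

Compound 4 `CC(C)(Oc1ccc(Cl)cc1)C(=O)NCCOC(=S)Nc1ccc(F)cc1` is not yet measured. It differs from compound 1 as follows: fluoro in place of methyl on an aromatic carbon. Because compound 1 at 661000 nM and compound 3 at 714000 nM lie within scatter despite unlike structures, no step beyond the scatter is expected from this change in either direction. Compound 4 is therefore expected to give 650000 nM in this assay, estimated between 330000 nM and 1300000 nM. The expected step of a 1.0-fold lower number from compound 1 to compound 4 (0.01 log units; within the scatter) is judged to be none beyond the scatter.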

Compound 4, half-maximal inhibitory concentration: 773000 nM
For compound 4 the middle estimate is 1.2-fold (0.08 log units) below the measured one; the range from low to high includes it.
By their numbers in this assay, from the lowest: compounds 2, 1, 3 and 4 (each within the scatter of the next).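

Among the compounds shown here, on the aromatic carbon para to a large group, fluoro in place of methyl gives the first step between compounds that differ in one place: in this assay it reads a 1.2-fold higher number from compound 1 to compound 4 (0.07 log units; within the scatter) and stays within the scatter. At this position 4-methylphenyl and 4-fluorophenyl therefore cannot be told apart on this read-out, and this change shows no effect beyond the scatter. No measurement at hand bears on the reason for this result.

From the compounds shown here alone, whether an amine, a carboxylic acid or a longer chain on this aromatic carbon would give a step beyond the scatter stays open. Going by these compounds, with each of the four numbers within the scatter of the next, it also stays open which part of the core of compound 1, if any, this read-out follows.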